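The source may hold more compounds than are shown below. What is called first, only, known or untested is meant among the compounds shown, and "the series" means these compounds.

Compound 1 `O=C1OC(c2ccc(OCc3ccccc3)cc2)C(c2ccc(O)cc2)=C1O` and compound 2 `O=C1OC(c2ccc(OCc3ccccc3)c(OCc3ccccc3)c2)C(c2ccc(F)cc2)=C1O` share one core and were both tested in an assay on blood for inhibition of Polyunsaturated fatty acid 5-lipoxygenase (Homo sapiens), tested at 10 uM; on this read-out lower numbers stand for a weaker effect and higher numbers for a stronger effect at the one concentration tested. Compound 1 gives 0%, and compound 2 gives 0%, level with compound 1 within the usual scatter. Compound 3 `O=C1OC(c2ccc(OCc3ccccc3)c(OCc3ccccc3)c2)C(c2ccc(O)cc2)=C1O` has not been measured; it differs from compound 2 in one place, (hydroxy in place of fluoro on an aromatic carbon). Compound 1 already carries the hydroxy group on that ring and is inactive, so the step from compound 2 to compound 3 is expected to be none beyond the scatter, estimated as no change at the digits printed from compound 2 to compound 3 (within the scatter). Compound 3 is therefore expected to give 0%, between 0% and 10%.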

Compound 3, a percentage reported as activity, at one concentration (the size of the read-out at that concentration, not a potency): 12.7%
For compound 3 the middle estimate is 12.7 percentage points below the measured one, and the stated range ends below it.
By their numbers in this assay, from the lowest: compounds 1 and 2 (each within the scatter of the next); then compound 3.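

In this assay, hydroxy in place of fluoro on this aromatic carbon gives a number 12.7 percentage points higher from compound 2 to compound 3 (beyond the scatter), and benzyloxy in place of hydrogen on the other ring gives a number 12.7 percentage points higher from compound 1 to compound 3 (beyond the scatter). Hydroxy alone, as in compound 1, and two benzyloxy groups with fluoro, as in compound 2, showed no separation, so a measurable effect appears here only where hydroxy and the second benzyloxy group occur together. The effect remains modest, and nothing measured explains this combination. On these data alone, whether an amine or a methoxy group in place of the hydroxy would keep the effect stays open.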